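Halogen on the triazole-bound ring: fluoro to bromo

The compounds below may be only part of what the source reports. "The series", "measured", "known", "first", "only" and "open" are said of these compounds alone.

Compound 1 `C/C(=C\CC/C(C)=C/CC[C@@H]1[C@@]2(C)CCC(=O)C(C)(C)[C@H]2CC[C@@]1(C)O)CC/C=C(\C)C(=O)OCc1cn(-c2cccc(O)c2)nn1` reaches only the limit > 150000 nM in a functional assay on U-87MG ATCC cells for antiproliferative activity against U-87 MG (Homo sapiens), read by MTT assay, with a stated time of 48 h; a lower number here means a stronger inhibitor, a higher number a weaker inhibitor. Compound 2 `C/C(=C\CC/C(C)=C/CC[C@@H]1[C@@]2(C)CCC(=O)C(C)(C)[C@H]2CC[C@@]1(C)O)CC/C=C(\C)C(=O)OCc1cn(-c2cccc(Cl)c2)nn1` gives 91800 nM in this assay. Compound 3 `C/C(=C\CC/C(C)=C/CC[C@@H]1[C@@]2(C)CCC(=O)C(C)(C)[C@H]2CC[C@@]1(C)O)CC/C=C(\C)C(=O)OCc1cn(-c2cccc(F)c2)nn1` likewise returns only the limit > 150000 nM in this assay, so it stands at the limit of > 150000 nM in this assay, at which 2 of the 3 values shown sit, and no number is known for it. Compound 4 `C/C(=C\CC/C(C)=C/CC[C@@H]1[C@@]2(C)CCC(=O)C(C)(C)[C@H]2CC[C@@]1(C)O)CC/C=C(\C)C(=O)OCc1cn(-c2cccc(Br)c2)nn1` differs from compound 3 by bromo in place of fluoro on an aromatic carbon. For the measured compounds named here, the steps that bear on this change are an at least 1.6-fold higher number from compound 2 to compound 3 (0.21 log units; that floor lies within the scatter) and an at least 1.6-fold lower number from compound 1 to compound 2 (0.21 log units; that floor lies within the scatter); both are floors within the scatter, and compound 1 against compound 3 shows two limits with no readable step. Going by the values given here, since compound 2, the chloro analogue, is the one that gave a number, compound 4 is expected to give a number of similar size, a step of an at least 1.5-fold lower number from compound 3 to compound 4 (0.19 log units; that floor lies within the scatter) toward a lower number in this assay. Compound 4 is therefore estimated at 95000 nM, between 45000 nM and 180000 nM, with a fair chance that only a limit is reported.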

Compound 4, half-maximal inhibitory concentration: 8750000 nM
Estimate against measurement, compound 4: 92-fold (1.96 log units) below; the measured number lies above the stated range.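

In this assay, for the compounds shown here, bromo in place of chloro on this aromatic carbon gives a 95-fold higher number from compound 2 to compound 4 (1.98 log units; beyond the scatter), the first step at this position that lies beyond the scatter, so the choice of halogen here can matter strongly. The steps to compound 4 from compound 1 and from compound 3 cannot be read, because those two compounds stop at a limit: the limit of > 150000 nM in this assay, at which 2 of the 4 values shown sit.

The compounds shown leave open whether an amine, a methoxy group or a carboxylic acid on this carbon would give a readable number, and whether any such group would match compound 2.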